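This account rests on a few compounds, and the source may have more. Where it says the series, first, only, none or still open, it means among the compounds named here.

Measured in a functional assay on MC-38 cells (Mus musculus) for antiproliferative activity, read by colorimetric assay and MTT assay; on this read-out higher numbers stand for weaker inhibition and lower numbers for stronger inhibition:
- compound 1 `COc1ccc(S(=O)(=O)Nc2cccc3cc[nH]c23)cc1`: 1.5 ug/mL
- compound 2 `O=S(=O)(Nc1cccc2cc[nH]c12)c1ccc(Cl)cc1`: 7 ug/mL
- compound 3 `O=[N+]([O-])c1ccc(S(=O)(=O)Nc2cccc3cc[nH]c23)cc1`: 7.2 ug/mL

In this assay compound 3, at 7.2 ug/mL, sits at the high-number end together with compound 2, a 1.0-fold higher number from compound 2 to compound 3 (0.01 log units; within the scatter), while the gap to the first compound is clear, a 4.8-fold higher number from compound 1 to compound 3 (0.68 log units; beyond the scatter).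

Compound 4 `O=[N+]([O-])c1ccc(S(=O)(=O)Nc2cccc3cc(Cl)[nH]c23)cc1` has chloro in place of hydrogen on an aromatic carbon of the five-membered aromatic ring, next to the ring nitrogen (chloro in place of hydrogen on an aromatic carbon).

Among the measured compounds shown here, no measured step touches that place. The nearest guides are modest swaps elsewhere, a 4.7-fold higher number from compound 1 to compound 2 (0.67 log units; beyond the scatter) and a 4.8-fold higher number from compound 1 to compound 3 (0.68 log units; beyond the scatter), so they bear only indirectly. As far as these compounds go, no change beyond the scatter is expected, and the direction stays open.

The expected step is a 1.6-fold lower number from compound 3 to compound 4 (0.20 log units; within the scatter).

For compound 4 the estimated value is 4.5 ug/mL, with an expected range of 1.2 ug/mL to 15 ug/mL.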

Compound 4, half-maximal inhibitory concentration: 19 ug/mL
The estimate for compound 4 lay 4.2-fold (0.63 log units) below the measured number; measured number outside the range, above it.
By their numbers in this assay, from the lowest: compound 1; then compounds 2 and 3 (each within the scatter of the next); then compound 4.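

In this assay, chloro in place of hydrogen next to the ring nitrogen gives a 2.6-fold higher number from compound 3 to compound 4 (0.42 log units; beyond the scatter) and so weakens inhibition beyond the scatter. Among the compounds shown here, the earlier steps only swapped methoxy, chloro and nitro elsewhere, so this is the first sign that this position responds to substitution, seen here with nitro retained. No data shown explain the shift. As far as these compounds go, whether chloro here has the same effect with methoxy in place of nitro remains open. From the compounds shown here alone, whether methyl, fluoro or an amine at this position would match chloro also remains open.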